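The source may hold more compounds than are shown below. What is called first, only, known or untested is meant among the compounds shown, and "the series" means these compounds.

Within the data shown here, compound 1, with the structure `CCCCC[Se]c1nc([Se]CCCCC)c2cccnc2n1`, is the one compound of this set for which a functional assay on MCF7 cells (Homo sapiens) for cytotoxicity, read by MTT assay, with a stated time of 72 h (on this read-out lower numbers stand for stronger inhibition of growth and higher numbers for weaker inhibition of growth), returns a number: compound 1 gives 67700 nM. Compound 2, with the structure `CSc1nc(NCCCCCO)c2cccnc2n1`, gives > 100000 nM in this assay, which is a limit of the assay rather than a number. Compound 3, with the structure `[SeH]c1nc(NCc2ccccc2)c2ccccc2n1`, likewise gives > 100000 nM in this assay, again a limit. So compound 1 stands at the only measured point, while the other two values rest at the limit of > 100000 nM in this assay, at which 2 of the 3 values shown sit.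

Compound 4, with the structure `CCCCC[Se]c1nc(N)c2cccnc2n1`, differs from compound 1 by one nitrogen atom in place of a group of 6 heavy atoms (5 carbon, 1 selenium; no ring), on an aromatic carbon. Among the measured compounds shown here, no measured pair in this set shows the effect of such a change, so the expectation can only lean on how weak every value shown is. The step from compound 1 to compound 4 is expected to be a 1.5-fold higher number from compound 1 to compound 4 (0.17 log units; within the scatter), which would carry compound 4 toward the limit rather than away from it. Compound 4 is therefore estimated at 100000 nM in this assay, with a plausible range from 30000 nM to 400000 nM, and a fair chance that only a limit is reported.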

Compound 4, concentration for total growth inhibition: 53800 nM
Compound 4: middle estimate off by 1.9-fold (0.27 log units), on the high side; the measured number falls inside the stated range.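

Putting amino in place of the group of 6 heavy atoms, on this aromatic carbon next to the ring nitrogen, gives a 1.3-fold lower number from compound 1 to compound 4 (0.10 log units; within the scatter) in this assay. This first measured pair shows that the change leaves the read-out within the scatter. Compound 4 also returns a number rather than a limit, so a measurable value here does not require the departing group at this position, while the set as a whole stays close to its ceiling: the limit of > 100000 nM in this assay, at which 2 of the 4 values shown sit.

The compounds shown leave open whether a substituted amine, a carboxylic acid or a longer chain on this carbon would move the number beyond the scatter. They also leave open what the selenium-bearing chain shared by compound 1 and compound 4 contributes, since no pair shown changes that group alone.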